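Aryl change at the carbon bound to sulfur: compound 4

The source may hold more compounds than are shown below. What is called first, only, known or untested is meant among the compounds shown, and "the series" means these compounds.

Three measured compounds share one core and differ only in the aromatic group on a saturated chain carbon bound to a sulfur. In an assay on HEK293 cells for inhibition of sodium-dependent dopamine transporter (Homo sapiens), read by scintillation counting, with stated times of 5 min and 1 min (on this read-out higher numbers stand for weaker inhibition and lower numbers for stronger inhibition), compound 1 `Cc1noc(C[S+]([O-])C(c2ccccc2)c2ccccc2)n1` gives 56700 nM; compound 2 `Cc1cnc(C[S+]([O-])C(c2ccccc2)c2ccccc2)nc1` gives 156000 nM; compound 3 `[O-][S+](Cc1ccncc1)C(c1ccccc1)c1ccccc1` gives 63500 nM. Compound 3 stands second highest of the three numbers. The step of a 1.1-fold higher number from compound 1 to compound 3 (0.05 log units; within the scatter) lies within the scatter, whereas the step of a 2.5-fold lower number from compound 2 to compound 3 (0.39 log units; beyond the scatter) is modest and beyond it, as is the step of a 2.8-fold higher number from compound 1 to compound 2 (0.44 log units; beyond the scatter).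

Compound 4 `[O-][S+](Cc1ccsc1Br)C(c1ccccc1)c1ccccc1` is not yet measured. The change is 2-bromothiophen-3-yl in place of pyridin-4-yl on a saturated chain carbon bound to a sulfur. Going by the values given here, no measured step involves this entering group; what bears on it are the three swaps of the aromatic group at the same place, each of which moved the number within the scatter or by a modest amount. The step of a 1.2-fold lower number from compound 3 to compound 4 (0.06 log units; within the scatter) is therefore expected to be small, with no direction established beyond the scatter. Compound 4 is estimated at 55000 nM, with a range from 18000 nM to 170000 nM in this assay.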

Compound 4, half-maximal inhibitory concentration: 29300 nM
Beside the measured number, compound 4's estimate is 1.9-fold (0.27 log units) above it; the measured number falls inside the stated range.
By their numbers in this assay, from the lowest: compounds 4, 1 and 3 (each within the scatter of the next, the first and the last beyond it); then compound 2.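

Notes on the aryl position: in this assay, 2-bromothiophen-3-yl is the first group at this place without a ring nitrogen, and it gives the first step beyond the scatter that does not involve compound 2 (a 2.2-fold lower number from compound 3 to compound 4 (0.34 log units; beyond the scatter)). The same group stays within the scatter against the other five-membered ring, 3-methyl-1,2,4-oxadiazol-5-yl (a 1.9-fold lower number from compound 1 to compound 4 (0.29 log units; within the scatter)), while the step from 5-methylpyrimidin-2-yl (a 5.3-fold lower number from compound 2 to compound 4 (0.73 log units; beyond the scatter)) is the widest in the set. No measurement on hand accounts for these steps.

Still open, on these data alone, is whether the step belongs to the bromine or to the thiophene ring; thiophen-3-yl without the bromine, or a plain phenyl, at this place would separate the two. Also open, as far as these compounds go, is how an amine or a carboxylic acid on the aromatic group would move the number.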